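The source may report more compounds than this note shows. Statements on the series, on what has been measured and on what is new or still open speak of the compounds shown alone.

In a functional assay on BMEC cells (Bos taurus) for antiproliferative activity (a lower number here means a stronger inhibitor, a higher number a weaker inhibitor), compound 1 `COc1cc(/C=C\Cc2cc(O)c3ccsc3c2)cc(OC)c1OC` gives 87 nM, while compound 2 `COc1cc(/C=C/Cc2cc(O)c3ccsc3c2)cc(OC)c1OC` gives 38700 nM. Compound 2 therefore has the higher of the two numbers and is the weaker inhibitor. The gap between them is large, a 440-fold higher number from compound 1 to compound 2 (2.65 log units; beyond the scatter), and it can be traced to the fact that compounds 1 and 2 differ only in the configuration as drawn: the double bond is drawn Z in compound 1 and E in compound 2.

Compound 3 `COc1cc(/C=C/Cc2cc(O)c3cc(-c4ccccc4)sc3c2)cc(OC)c1OC` keeps the E double bond of compound 2 and differs from it in one place: phenyl in place of hydrogen on an aromatic carbon. This puts phenyl in place of hydrogen on an aromatic carbon, next to the ring sulfur. Within the data shown here, the only measured step, a 440-fold higher number from compound 1 to compound 2 (2.65 log units; beyond the scatter), concerns the double bond, so no measured step shows what a new phenyl does here. With the E double bond retained, compound 3 is expected to stay close to compound 2 in this assay, with no step beyond the scatter, although the uncertainty is wide. The estimated step is a 1.3-fold lower number from compound 2 to compound 3 (0.11 log units; within the scatter). Compound 3 is thus expected at 30000 nM, within an estimated range of 5000 nM to 100000 nM.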

Compound 3, half-maximal inhibitory concentration: 38000 nM
Compound 3: the middle estimate sits 1.3-fold (0.10 log units) below what was measured; the range from low to high includes it.
By their numbers in this assay, from the lowest: compound 1; then compounds 3 and 2 (each within the scatter of the next).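

In this assay, the step of a 1.0-fold lower number from compound 2 to compound 3 (0.01 log units; within the scatter) shows that the aromatic carbon next to the ring sulfur can carry a phenyl, with 6 heavy atoms where there was only a hydrogen, and the number stays within the scatter. Among these compounds, this is the first look at a change on the shared core itself rather than at the double bond, but it comes from the E compounds, and the step of a 440-fold higher number from compound 1 to compound 2 (2.65 log units; beyond the scatter) has already placed compound 2 far on the weak side, so the flat result describes only that weak setting. The evidence at hand offers no explanation for why the phenyl leaves the number unmoved.

From the compounds shown here alone, it remains open whether the same phenyl would be tolerated on the Z double bond of compound 1, where there is much more activity to lose. Going by these compounds, it is equally open how this position would respond to a different kind of group, such as an amine, a carboxylic acid or a small methyl, and whether any of these could bring an E compound closer to compound 1.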